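This account rests on a few compounds, and the source may have more. Where it says the series, first, only, none or still open, it means among the compounds named here.

Compound 3, `CCN1CCc2c(c(C(C)(C)C)nn2C(=O)Nc2cc(C)ccc2C)C1`, gives 0% in a functional assay on the whole organism (strain Swiss albino) for inhibition, with Mus musculus as the target, in the formalin test, with stated times of 30 min and 5 min, at a dose of 100 mg/kg (a higher number here means more inhibition at the dose given (going by the name of the read-out), a lower number less inhibition), the lowest of the three numbers measured. For the measured compounds named here, compound 2, `CCN1CCc2c(c(C(C)(C)C)nn2C(=O)Nc2c(C)cccc2C)C1`, gives 15.7%; the step of a number 15.7 percentage points lower from compound 2 to compound 3 (beyond the scatter) is the only single change measured so far. Compound 1, `CCN1CCc2c(c(C)nn2C(=O)Nc2ccc(F)cc2F)C1`, gives 7.8%, which sits within the scatter of compound 3. Compound 4, `CCN1CCc2c(c(C(C)(C)C)nn2C(=O)Nc2ccc(F)cc2F)C1`, differs from compound 3 by 2,4-difluorophenyl in place of 2,5-dimethylphenyl on an amide-type nitrogen. Going by the values given here, no measured step bears directly on this change; compound 1 carries the same 2,4-difluorophenyl group, yet also differs in another place, so its value only hints that the difluorophenyl compounds stay low. The step of a number 5 percentage points higher from compound 3 to compound 4 (within the scatter) is therefore expected to stay within the scatter. Compound 4 is estimated at 5%, within 0% to 18%.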

Compound 4, a percentage reported as inhibition, in the whole organism at one dose (the size of the read-out at that dose, not a potency): 4.4%
The estimate for compound 4 lay 0.6 percentage points above the measured number; the measured number falls inside the stated range.
By their numbers in this assay, from the lowest: compounds 3, 4, 1 and 2 (each within the scatter of the next, the first and the last beyond it).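

In this assay, the step of a number 4.4 percentage points higher from compound 3 to compound 4 (within the scatter) leaves 2,4-difluorophenyl and 2,5-dimethylphenyl on the amide-type nitrogen indistinguishable, whereas the step of a number 11.3 percentage points lower from compound 2 to compound 4 (beyond the scatter) sets 2,6-dimethylphenyl apart from 2,4-difluorophenyl as well as from 2,5-dimethylphenyl. For the compounds shown here, the step of a number 3.4 percentage points lower from compound 1 to compound 4 (within the scatter) adds a first comparison at the aromatic carbon and shows no clear difference between tert-butyl and methyl when 2,4-difluorophenyl is present. Nothing available explains these results. On these data alone, it remains open how a methoxyphenyl group on the amide-type nitrogen, or a longer chain in place of tert-butyl, would compare.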